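The source may hold more compounds than are shown below. What is called first, only, known or untested is meant among the compounds shown, and "the series" means these compounds.

Of the compounds shown here, three have been measured in an assay on HEK293 cells for agonist activity at transient receptor potential cation channel subfamily M member 8 (Homo sapiens), read by fluorescence and calcium flux, with a stated time of 15 min; on this read-out higher numbers stand for an effect only at larger amounts of compound and lower numbers for an effect already at smaller amounts. Compound 1 `COc1ccc2oc(C(=O)N(Cc3cccs3)c3ccn[nH]3)cc2c1` gives 1.1 nM, compound 3 `COCCN(Cc1cccs1)C(=O)COc1ccc(C)cc1` gives 400 nM, and compound 2 `CCN(Cc1cc[nH]c1)C(=O)COc1ccc(C)cc1` gives 21800 nM, the highest number of the three, with both other compounds far below it and both gaps beyond the usual scatter. Compound 2 therefore stands at the weak end of what has been seen so far, and compound 3 is the nearer of the other two.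

The step considered here leads from compound 2 to compound 4 `CCN(Cc1cncs1)C(=O)COc1ccc(C)cc1`, which has not yet been measured. The change is 1,3-thiazol-5-yl in place of 1H-pyrrol-3-yl on a saturated chain carbon bound to an amide-type nitrogen. For the measured compounds named here, no measured pair in this set differs in this place alone, so there is no direct guide to the size of the step. Compound 3 and compound 1 give lower numbers than compound 2, but each differs from it in several places at once, so they hint at a direction and not at a size. A moderate move toward lower numbers is expected, a 5.5-fold lower number from compound 2 to compound 4 (0.74 log units; beyond the scatter). The estimate for compound 4 in this assay is 4000 nM, expected to fall between 1000 nM and 15000 nM.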

Compound 4, half-maximal effective concentration: 1100 nM
For compound 4 the middle estimate is 3.6-fold (0.56 log units) above the measured one, within the range that was stated.
By their numbers in this assay, from the lowest: compound 1; then compound 3; then compound 4; then compound 2.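

In this assay, for the compounds shown here, putting 1,3-thiazol-5-yl in place of 1H-pyrrol-3-yl gives a 20-fold lower number from compound 2 to compound 4 (1.30 log units; beyond the scatter) with the rest of the molecule untouched, so this is the first sign that the ring on this saturated chain carbon bound to an amide-type nitrogen matters by itself, and that its effect is large. The earlier compounds shown here could not show this, since each of them differs from compound 2 in several places at once. Both rings are five-membered and aromatic with the same count of heavy atoms, yet the entering ring has lost the hydrogen-bond donor of the leaving ring and brings in sulfur and a second hetero atom, and nothing available here shows which of these differences accounts for the step.

The compounds shown leave open whether a ring with no hetero atom at all, such as phenyl, or another ring without the donor, such as furan-3-yl, would give a similar step at this place. They also leave open whether the step keeps its size when the ethyl group on the amide nitrogen gives way to a longer chain.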